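Replacing a benzylamine arm with a hindered amino alcohol

The source may report more compounds than this note shows. Statements on the series, on what has been measured and on what is new or still open speak of the compounds shown alone.

Measured compounds, with their results in an assay on CHO cells for agonist activity at 5-hydroxytryptamine receptor 1D (Homo sapiens), read by GTPgammaS binding; a higher number here means that more compound is needed for the effect, a lower number that less compound is needed:
- compound 1 `O=S(=O)(NCC1CCN(CCCc2c[nH]c3ccc(-n4cnnc4)cc23)CC1)c1ccccc1` gives 12 nM
- compound 2 `C[C@@H](NC1CCN(CCCc2c[nH]c3ccc(-n4cnnc4)cc23)CC1)c1ccccc1` gives 13 nM
- compound 3 `c1ccc(CNCC2CCN(CCCc3c[nH]c4ccc(-n5cnnc5)cc34)CC2)cc1` gives 5.6 nM

Among these three, compound 3 has the lowest number, and both steps toward it go beyond the scatter: a 2.1-fold lower number from compound 1 to compound 3 (0.33 log units; beyond the scatter) and a 2.3-fold lower number from compound 2 to compound 3 (0.37 log units; beyond the scatter). Compound 1 and compound 2 sit within the scatter of each other, as a 1.1-fold higher number from compound 1 to compound 2 (0.03 log units; within the scatter) shows.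

Compound 4 `CC(CO)(NC1CCN(CCCc2c[nH]c3ccc(-n4cnnc4)cc23)CC1)c1ccccc1` has not yet been measured in this assay. It differs from compound 3 in one place: (1-(hydroxymethyl)-1-phenylethyl)amino in place of (benzylamino)methyl on a saturated ring carbon. The new group resembles that of compound 2, an amine attached directly to the saturated ring carbon and carrying a phenyl-bearing carbon, but now with an extra methyl and a hydroxymethyl on that carbon. The step that bears most directly on this change is a 2.3-fold lower number from compound 2 to compound 3 (0.37 log units; beyond the scatter), a modest change. Reversing that kind of change points to a modest rise in the number, roughly back toward the level of compound 2, with added uncertainty from the two groups that have no counterpart among the measured compounds. The step is therefore expected to be about a 2.7-fold higher number from compound 3 to compound 4 (0.43 log units; beyond the scatter). Compound 4 is expected to give about 15 nM, within a range from 6 nM to 40 nM.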

Compound 4, half-maximal effective concentration: 3.4 nM
Compound 4: the middle estimate sits 4.4-fold (0.64 log units) above what was measured; measured number below the stated range.
By their numbers in this assay, from the lowest: compounds 4 and 3 (each within the scatter of the next); then compounds 1 and 2 (each within the scatter of the next).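

In this assay, (1-(hydroxymethyl)-1-phenylethyl)amino can stand in place of (benzylamino)methyl on this saturated ring carbon with no change that can be told from the scatter, as a 1.6-fold lower number from compound 3 to compound 4 (0.22 log units; within the scatter) shows. The more telling comparison is with compound 2, which also has its amine attached directly to the ring carbon: adding a methyl and a hydroxymethyl to the phenyl-bearing carbon goes with a 3.8-fold lower number from compound 2 to compound 4 (0.58 log units; beyond the scatter), and the comparison with the sulfonamide gives a 3.5-fold lower number from compound 1 to compound 4 (0.55 log units; beyond the scatter). An amine attached directly to this ring carbon therefore does not by itself hold the number at the level of compound 2, although nothing available here explains the difference.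

The methyl and the hydroxymethyl arrive together in compound 4, so the compounds shown cannot say which of the two goes with the lower number. An arm carrying only a hydroxymethyl on that carbon, or a methoxymethyl in its place, would separate the two and test whether the hydroxyl itself matters.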